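Trimming the Chain End to a Formyl Group

This account rests on a few compounds, and the source may have more. Where it says the series, first, only, none or still open, it means among the compounds named here.

Compound 2 `CC(C)(C)C(=O)OCCCCCCCCCCCCCCC/C=C1\CC(CO)(COC(=O)C(C)(C)C)OC1=O` gives 0.352 ug/mL in a functional assay on K562 cells (Homo sapiens) for antiproliferative activity; a higher number here means a weaker inhibitor of growth, a lower number a stronger inhibitor of growth; this is the highest of the two numbers, yet it sits within the scatter of compound 1 `COCCCCCCCCCCCCCCC/C=C1\CC(CO)(COC(=O)C(C)(C)C)OC1=O`, which gives 0.189 ug/mL. Compound 3 `CC(C)(C)C(=O)OCC1(CO)C/C(=C\CCCCCCCCCCCCCCC=O)C(=O)O1` differs from compound 2 by formyl in place of (((tert-butyl)carbonyl)oxy)methyl on a saturated chain carbon, ten or more bonds along the chain from a double-bonded chain carbon. Going by the values given here, the only measured step at that chain end, a 1.9-fold higher number from compound 1 to compound 2 (0.27 log units; within the scatter), stayed within the scatter, so the data give no sign of a large movement when this end of the chain is altered. Compound 3 is therefore expected to come in near 0.3 ug/mL, between 0.1 ug/mL and 0.9 ug/mL, an estimated step of a 1.2-fold lower number from compound 2 to compound 3 (0.07 log units; within the scatter) that is not expected to exceed the scatter.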

Compound 3, concentration for 50% growth inhibition: 5.11 ug/mL
Estimate against measurement, compound 3: 17-fold (1.23 log units) below; the whole stated range lies below it.
By their numbers in this assay, from the lowest: compounds 1 and 2 (each within the scatter of the next); then compound 3.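

In this assay the chain end proves sensitive after all: formyl in place of (((tert-butyl)carbonyl)oxy)methyl brings a 15-fold higher number from compound 2 to compound 3 (1.16 log units; beyond the scatter) and formyl in place of methoxymethyl brings a 27-fold higher number from compound 1 to compound 3 (1.43 log units; beyond the scatter) while the two earlier chain ends stay within the scatter of each other. This position thus accepts either of those two groups, yet formyl costs much of the growth inhibition. No measurement at hand bears on why this happens. The compounds shown leave open whether a carboxylic acid, a hydroxymethyl group or an amine at this chain end would track formyl or methoxymethyl, and what a longer chain would do.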